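The source may report more compounds than this note shows. Statements on the series, on what has been measured and on what is new or still open speak of the compounds shown alone.

Of the compounds shown here, two that share one core have so far been tested in a physicochemical assay for solubility, read by HPLC; on this read-out higher numbers stand for higher solubility and lower numbers for lower solubility. Compound 1 `CC1COC2(CCN(c3nc(=O)c4cc(C(F)(F)F)cc([N+](=O)[O-])c4s3)CC2)O1` gives 0.94 ug/mL in this assay. Compound 2 `CCCC(=O)N1CCN(c2nc(=O)c3cc(C(F)(F)F)cc([N+](=O)[O-])c3s2)CC1` gives 2.46 ug/mL in this assay. Of these two numbers, compound 2 holds the higher one, and its gap to compound 1 lies beyond the usual scatter of repeated measurements, so the two compounds can be told apart on this read-out.

The next compound, compound 3 `O=C(c1ccccc1Cl)N1CCN(c2nc(=O)c3cc(C(F)(F)F)cc([N+](=O)[O-])c3s2)CC1`, has not yet been measured in this assay. It is made from compound 2 by a single change on the carbonyl carbon that sits on the amide-type nitrogen in a ring: 2-chlorophenyl in place of propyl on a carbonyl carbon. Going by the values given here, no measured pair in this small set shows such a change, so there is no step to lean on, only the two values themselves.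

The step from compound 2 to compound 3 in this assay is expected to be a 2.5-fold lower number from compound 2 to compound 3 (0.39 log units; beyond the scatter). For compound 3 the estimated solubility is 1 ug/mL, with a likely range from 0.4 ug/mL to 2.5 ug/mL.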

Compound 3, solubility: 8.18 ug/mL
For compound 3 the middle estimate is 8.2-fold (0.91 log units) below the measured one; the measured number lies above the stated range.
By their numbers in this assay, from the lowest: compound 1; then compound 2; then compound 3.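

On the carbonyl carbon that sits on the amide-type nitrogen in a ring, putting 2-chlorophenyl in place of propyl gives in this assay a step of a 3.3-fold higher number from compound 2 to compound 3 (0.52 log units; beyond the scatter). Going by these compounds alone, this is the first sign that the read-out responds to what stands at this position, and the step is one that repeated measurement would not be expected to blur. It also shows that, in this pair, a group with more heavy atoms and an aromatic ring goes with a higher number rather than a lower one, though nothing shown here explains why and the finding rests on a single pair.

The change brings in a ring and a chlorine at once, so this pair cannot say which of them goes with the step, and a plain phenyl on the same carbonyl carbon would help to separate the two. Going by these compounds, how a longer alkyl chain or a group carrying an amine would read at this position remains open, as does whether the same change would give a similar step on a different core.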